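The compounds below may be only part of what the source reports. "The series", "measured", "known", "first", "only" and "open" are said of these compounds alone.

Working notes on the series.

Of the compounds shown here, three share a core and have been measured in a functional assay on K562 cells (Homo sapiens) for cytotoxicity, read by MTT assay, with a stated time of 24 h; a lower number here means a stronger inhibitor, a higher number a weaker inhibitor. Compound 1 `Cc1ccc(NS(=O)(=O)c2ccc(-c3ccccc3)cc2)cc1Nc1nccc(-c2cccnc2)n1` gives 9490 nM in this assay. Compound 2 `Cc1ccc(NS(=O)(=O)c2cnc3ccccc3c2)cc1Nc1nccc(-c2cccnc2)n1` gives 5880 nM, and compound 3 `COc1cc(-c2ccnc(Nc3cc(NS(=O)(=O)c4ccc(-c5ccccc5)cc4)ccc3C)n2)cc(OC)c1OC` gives 5600 nM. Compound 3 carries the lowest of the three numbers, but it is not separated beyond the scatter from either of the others: a 1.7-fold lower number from compound 1 to compound 3 (0.23 log units; within the scatter), and against compound 2 the gap is smaller still. Likewise a 1.6-fold lower number from compound 1 to compound 2 (0.21 log units; within the scatter).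

Compound 4 `COc1ccc(S(=O)(=O)Nc2ccc(C)c(Nc3nccc(-c4cc(OC)c(OC)c(OC)c4)n3)c2)cc1` is the next member. Relative to compound 3 the change is methoxy in place of phenyl on an aromatic carbon. Within the data shown here, no measured step alters this sulfonyl-bound aryl in exactly this way; the closest precedent is the exchange at the same position from compound 1 to compound 2, which stayed within the scatter, and the exchange at the other end of the core from compound 1 to compound 3, which also stayed within the scatter. With two changes at both ends of the molecule leaving the numbers essentially unmoved, the expectation for compound 4 in this assay is no change at the digits printed from compound 3 to compound 4 (within the scatter), that is, no step beyond the scatter in either direction. Compound 4 is therefore estimated at 5600 nM, with a range from 2500 nM to 12000 nM.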

Compound 4, half-maximal inhibitory concentration: 9120 nM
The estimate for compound 4 lay 1.6-fold (0.21 log units) below the measured number, within the range that was stated.
By their numbers in this assay, from the lowest: compounds 3, 2, 4 and 1 (each within the scatter of the next).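

In this assay, replacing 4-phenylphenyl with 4-methoxyphenyl on the sulfonyl sulfur gives a 1.6-fold higher number from compound 3 to compound 4 (0.21 log units; within the scatter). This is a second exchange at this position that stays within the scatter, alongside the quinolin-3-yl exchange (a 1.6-fold lower number from compound 1 to compound 2 (0.21 log units; within the scatter)), and it is read with 3,4,5-trimethoxyphenyl rather than pyridin-3-yl at the other end of the shared core. The new step also shows that the terminal phenyl, with its 6 heavy atoms and six-membered aromatic ring of carbon only, can give way to methoxy, with 2 heavy atoms and no ring, without a step beyond the scatter, although no evidence in hand bears on the reason for this result.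

The compounds shown leave open whether any group at this position can move the number beyond the scatter, for example an amine or a carboxylic acid in place of methoxy, or a longer chain such as butoxy. They also leave open whether 4-methoxyphenyl on the sulfonyl sulfur gives a similar number when pyridin-3-yl stands at the other end of the core.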